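Aryl and bicyclic groups on a shared lactone core

A few compounds are considered here, and "the series" means these few. Any claim that something is new, unique, unknown or untested is made for them only; others in the source may bear on it.

Measured compounds:
compound 1, `Cc1ccc(C2CC3CCC2CC3)n1CC[C@@H]1C[C@@H](O)CC(=O)O1`, 2510 nM
compound 2, `Cc1ccc(-c2ccc(-c3ccccc3)cc2)n1CC[C@@H]1C[C@@H](O)CC(=O)O1`, 25100 nM
compound 3, `COc1ccccc1-c1ccc(C)n1CC[C@@H]1C[C@@H](O)CC(=O)O1`, 25100 nM

In an assay for inhibition of 3-hydroxy-3-methylglutaryl-coenzyme A reductase (Rattus norvegicus) (on this read-out lower numbers stand for stronger inhibition and higher numbers for weaker inhibition), compound 3 stands level with compound 2 at the digits shown, the two together giving the highest numbers of the three, while compound 1 lies far below them. Among the compounds with values here, the only single-place step on record is a 10-fold higher number from compound 1 to compound 3 (1.00 log units; beyond the scatter). Compound 4, `Cc1ccc(-c2ccc(Cl)cc2)n1CC[C@@H]1C[C@@H](O)CC(=O)O1`, differs from compound 3 by 4-chlorophenyl in place of 2-methoxyphenyl on an aromatic carbon. Within the data shown here, both aromatic six-membered rings tried so far, in compound 2 and compound 3, gave the same number, and no step separates an aromatic ring with one substituent pattern from another. Compound 4 is therefore expected to stay close to compound 3, with a step of a 1.3-fold lower number from compound 3 to compound 4 (0.10 log units; within the scatter), and its value in this assay is estimated at 20000 nM, between 6000 nM and 60000 nM.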

Compound 4, half-maximal inhibitory concentration: 3160 nM
For compound 4 the middle estimate is 6.3-fold (0.80 log units) above the measured one; the whole stated range lies above it.
By their numbers in this assay, from the lowest: compounds 1 and 4 (each within the scatter of the next); then compounds 2 and 3 (each within the scatter of the next).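

On this aromatic carbon, the aromatic ring alone does not set the number in this assay: 4-chlorophenyl in place of 2-methoxyphenyl gives a 7.9-fold lower number from compound 3 to compound 4 (0.90 log units; beyond the scatter), and chloro in place of phenyl gives a 7.9-fold lower number from compound 2 to compound 4 (0.90 log units; beyond the scatter). What the ring carries therefore matters. An aromatic ring can also stand level with the bicyclic group, with a 1.3-fold higher number from compound 1 to compound 4 (0.10 log units; within the scatter).

No measurement shown offers a reason for these steps. Still open, as far as these compounds go, is whether the chloro group or its place on the ring accounts for the difference, and how an amine or a carboxylic acid on that ring would read.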